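A few compounds are considered here, and "the series" means these few. Any claim that something is new, unique, unknown or untested is made for them only; others in the source may bear on it.

Working notes on the series.

Compound 2 `COc1cc(N2C(=O)[C@@H](Oc3ccccc3)[C@H]2c2ccc3ccccc3c2)cc(OC)c1OC` gives 282000 nM in a functional assay on MCF7 cells (Homo sapiens) for antiproliferative activity, read by MTT assay, with stated times of 24 h and 72 h (on this read-out lower numbers stand for stronger inhibition and higher numbers for weaker inhibition), and stands highest of the three numbers measured. Compound 1 `COc1cc(N2C(=O)[C@@H](Oc3ccccc3)[C@H]2c2ccc(C#N)cc2)cc(OC)c1OC` gives 31600 nM in this assay, and compound 3 `COc1ccc(N2C(=O)[C@@H](Oc3ccccc3)[C@H]2c2ccc(OC)c(O)c2)cc1` gives 49000 nM. Among the compounds with values here, the one step that bears on the saturated ring carbon is an 8.9-fold higher number from compound 1 to compound 2 (0.95 log units; beyond the scatter), a modest rise that lies beyond the scatter.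

Compound 4 `COc1ccc([C@@H]2[C@H](Oc3ccccc3)C(=O)N2c2cc(OC)c(OC)c(OC)c2)c([N+](=O)[O-])c1O` is the next member to be measured. It differs from compound 2 by a group of 12 heavy atoms (7 carbon, 1 nitrogen, 4 oxygen; one six-membered aromatic ring of carbon only) in place of a group of 10 heavy atoms (10 carbon; 2 six-membered aromatic rings of carbon only), on a saturated ring carbon. Compound 3 also carries an oxygenated phenyl at this carbon, but it differs from compound 2 elsewhere as well, so its number can only be read alongside the others, not as a step.

Since naphthalen-2-yl gave the highest number of the three, and the group entering in compound 4 is closer to the substituted phenyls of compound 1 and compound 3, the number for compound 4 is expected to move back downward, a 7.1-fold lower number from compound 2 to compound 4 (0.85 log units; beyond the scatter). Compound 4 is estimated at 40000 nM, within 10000 nM to 160000 nM.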

Compound 4, half-maximal inhibitory concentration: 89000 nM
Estimate against measurement, compound 4: 2.2-fold (0.35 log units) below; measured number inside the range.
By their numbers in this assay, from the lowest: compounds 1, 3 and 4 (each within the scatter of the next, the first and the last beyond it); then compound 2.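

Within the shared core, the single-ring group of compound 4 in place of naphthalen-2-yl gives a 3.2-fold lower number from compound 2 to compound 4 (0.50 log units; beyond the scatter) in this assay, so this saturated ring carbon responds to the exchange in both directions once compound 1 is included. The same group set against 4-cyanophenyl gives a 2.8-fold higher number from compound 1 to compound 4 (0.45 log units; beyond the scatter), which shows that a single six-membered aromatic ring at this carbon does not by itself fix the number, and the larger group with more hydrogen-bond acceptors sits between the other two. Nothing at hand gives a reason for either step.

The compounds shown leave open which substituent of the entering group carries these differences, since several change together. Also open, from the compounds shown here alone, is how the series would read with a piperidine or a carboxylic acid at this carbon, or with an amine in place of the phenoxy group present in every compound.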